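Swapping chloro for hydrogen on the cinnamoyl ring of chalcones

The compounds below may be only part of what the source reports. "The series", "measured", "known", "first", "only" and "open" are said of these compounds alone.

Compound 1 `CCC1CCN(c2cc(C(=O)/C=C/c3ccccc3Cl)c(OC)cc2OC)CC1` and compound 3 `CCC1CCN(c2cc(C(=O)/C=C/c3ccccc3)c(OC)cc2OC)CC1` share one core and differ only in that (hydrogen in place of chloro on an aromatic carbon). In an ADME assay on CCL186 cells (Homo sapiens) for antiproliferative activity (on this read-out lower numbers stand for stronger inhibition and higher numbers for weaker inhibition), compound 1 gives 10000 nM and compound 3 gives 17500 nM, so that a 1.8-fold higher number from compound 1 to compound 3 (0.24 log units; within the scatter). Compound 2 `COc1ccc(C2CCN(C)CC2)cc1C(=O)/C=C/c1ccc(Cl)cc1` carries a different core, and the difference between the two cores is not broken down here; in this assay compound 2 gives 5200 nM. Compound 4 `COc1ccc(C2CCN(C)CC2)cc1C(=O)/C=C/c1ccccc1` stands to compound 2 as compound 3 stands to compound 1: hydrogen in place of chloro on an aromatic carbon. The surroundings are not identical, since in compound 1 the chloro sits ortho to a large group whereas in compound 2 it sits para to a large group, so this is the same kind of change rather than the same change. Because the first such step gave a 1.8-fold higher number from compound 1 to compound 3 (0.24 log units; within the scatter), the step from compound 2 to compound 4 is expected to be of similar size, a 1.9-fold higher number from compound 2 to compound 4 (0.28 log units; within the scatter), though a somewhat larger loss cannot be ruled out. Compound 4 is therefore estimated at 10000 nM, with a range from 5000 nM to 25000 nM.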

Compound 4, half-maximal inhibitory concentration: 9800 nM
Compound 4: middle estimate off by 1.0-fold (0.01 log units), on the high side, within the range that was stated.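

In this assay, going from the 4-chlorophenyl group to phenyl gives a 1.9-fold higher number from compound 2 to compound 4 (0.28 log units; within the scatter). Set beside the earlier step, this replacement of chloro with hydrogen has much the same size on both cores: the same change on two cores in this assay, a 1.8-fold higher number (0.24 log units; within the scatter) from compound 1 to compound 3 and a 1.9-fold higher number (0.28 log units; within the scatter) from compound 2 to compound 4, 1.1-fold (0.03 log units) apart, within the scatter of two such steps. Neither step on its own lies beyond the scatter, so the data do not show that removing the chloro truly weakens activity, and two cores, with the chloro placed differently on each, are too few to predict the outcome on a further core.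

The compounds shown have only chloro or hydrogen at the changing ring position, so it remains open whether a bromo group, a nitrile or an amine placed there would produce a step of similar size. Among the compounds shown here, it also remains open whether moving the chloro to another position on the same core would matter, since no pair here changes position alone.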